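Ethoxycarbonyl in place of (ethoxycarbonyl)methyl on compound 1

The source may hold more compounds than are shown below. What is called first, only, known or untested is meant among the compounds shown, and "the series" means these compounds.

- compound 1 `CCCCCCCCc1ccc(OCC(=O)c2nc(CC(=O)OCC)cs2)cc1` reads 5000 nM
- compound 2 `CCCCCCCCCCCCOCC(=O)c1nc(C(=O)OCC)cs1` reads "not active" (no number reported)

Within the data shown here, in a functional assay on SW982 cells (Homo sapiens) for inhibition, read by scintillation counting (a lower number here means a stronger inhibitor, a higher number a weaker inhibitor), compound 1 stands at 5000 nM as the only number available, with no comparison to place it against. Compound 3 `CCCCCCCCc1ccc(OCC(=O)c2nc(C(=O)OCC)cs2)cc1` carries ethoxycarbonyl in place of (ethoxycarbonyl)methyl on an aromatic carbon. Among the measured compounds shown here, compound 2 bears the same ethoxycarbonyl and is reported as "not active" (no number reported), but it differs elsewhere too, so no measured step isolates this change. The expected change, a 1.3-fold lower number from compound 1 to compound 3 (0.10 log units; within the scatter), is none beyond the scatter, with no firm direction. Compound 3 is estimated at 4000 nM, within an expected range of 800 nM to 20000 nM, though a result without a number remains possible.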

Compound 3, half-maximal inhibitory concentration: 600 nM
Compound 3: the middle estimate sits 6.7-fold (0.82 log units) above what was measured, and the stated range ends above it.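

In this assay, ethoxycarbonyl in place of (ethoxycarbonyl)methyl on this aromatic carbon gives an 8.3-fold lower number from compound 1 to compound 3 (0.92 log units; beyond the scatter), a step beyond the scatter. This position therefore responds clearly to the change, even though the leaving and entering groups have the same counts of hydrogen-bond donors and acceptors. No measurement shown accounts for the step. The compounds shown leave open how a carboxylic acid or a primary amide would read on this aromatic carbon. They also leave open whether the step would hold with a dodecyl ether in the rest of the molecule.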